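Series notes: aryl swap at the chalcone end

The source may report more compounds than this note shows. Statements on the series, on what has been measured and on what is new or still open speak of the compounds shown alone.

Measured so far:
compound 1 `O=C(COc1ccc(C(=O)/C=C/c2ccccc2Cl)cc1)N[C@H]1CCOC1=O` — 17400 nM
compound 2 `COc1ccccc1/C=C/C(=O)c1ccc(OCC(=O)N[C@H]2CCOC2=O)cc1` — > 64000 nM

In a functional assay on MCF7 cells (Homo sapiens) for antiproliferative activity, read by MTT assay, with a stated time of 72 h (on this read-out higher numbers stand for weaker inhibition and lower numbers for stronger inhibition), compound 1 gives 17400 nM. For compound 2 the read-out is only a limit of the assay, > 64000 nM; see (the limit of > 64000 nM in this assay, at which 1 of the 2 values shown sits). Compound 3 `CC(C)(C)c1ccc(/C=C/C(=O)c2ccc(OCC(=O)N[C@H]3CCOC3=O)cc2)cc1` carries 4-(tert-butyl)phenyl in place of 2-methoxyphenyl on a double-bonded chain carbon bound to a double-bonded chain carbon. Going by the values given here, the sole measured step, an at least 3.6-fold higher number from compound 1 to compound 2 (0.56 log units; beyond the scatter), concerns a different group and only sets a floor for compound 2, so it bears on compound 3 indirectly. A return towards the range of compound 1 is expected, an at least 2.1-fold lower number from compound 2 to compound 3 (0.32 log units; beyond the scatter), with a real chance of another limit. Compound 3 is estimated at 30000 nM, between 8000 nM and 100000 nM.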

Compound 3, half-maximal inhibitory concentration: 16400 nM
Estimate against measurement, compound 3: 1.8-fold (0.26 log units) above; the range from low to high includes it.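

With 4-(tert-butyl)phenyl at this place on a double-bonded chain carbon bound to a double-bonded chain carbon, this assay gives an at least 3.9-fold lower number from compound 2 to compound 3 (0.59 log units; beyond the scatter). Compound 2 remains a limit of the assay, so that step gives only a minimum size: the limit of > 64000 nM in this assay, at which 1 of the 3 values shown sits. Replacing 2-chlorophenyl with 4-(tert-butyl)phenyl gives a 1.1-fold lower number from compound 1 to compound 3 (0.03 log units; within the scatter), so among these three compounds, only 2-methoxyphenyl stands apart.

As far as these compounds go, how far compound 2 actually lies from the other two stays open. Also open, from the compounds shown here alone, is whether an amine or a carboxylic acid on this phenyl ring would hold the read-out at this level or shift it.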